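The source may report more compounds than this note shows. Statements on the series, on what has been measured and on what is new or still open speak of the compounds shown alone.

Values in a functional assay on CNE-2 cells (Homo sapiens) for antiproliferative activity, read by sulforhodamine B assay, with a stated time of 48 h; a lower number here means a stronger inhibitor, a higher number a weaker inhibitor
- compound 1 `COc1ccc(/C=C/C(=O)c2ccccc2-c2cccc(F)c2)cc1` gives 73 nM
- compound 2 `COc1ccc(/C=C/C(=O)c2ccccc2-c2ccc(F)nc2)cc1` gives 160 nM

Compound 2 has the higher of the two numbers, so it is the weaker inhibitor, and its gap to compound 1 lies beyond the scatter. Going by the values given here, the only measured step is a 2.2-fold higher number from compound 1 to compound 2 (0.34 log units; beyond the scatter), which is modest in size. It replaces the 3-fluorophenyl group with 6-fluoropyridin-3-yl, so it bears on the same substituent but does not isolate the fluoro.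

Next is compound 3 `COc1ccc(/C=C/C(=O)c2ccccc2-c2cccnc2)cc1`, with hydrogen in place of fluoro on an aromatic carbon relative to compound 2: hydrogen in place of fluoro on an aromatic carbon. The same difference reads 6-fluoropyridin-3-yl to pyridin-3-yl. Among the compounds with values here, no measured pair shows this change directly, so the estimate stays close to compound 2 at 160 nM and the range is kept wide. In this assay, a step no larger than the modest one measured is expected, leaning slightly towards a higher number. The expected change is a 1.3-fold higher number from compound 2 to compound 3 (0.12 log units; within the scatter). For compound 3 the estimated value is 210 nM, with an expected range of 90 nM to 500 nM.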

Compound 3, half-maximal inhibitory concentration: 64 nM
For compound 3 the middle estimate is 3.3-fold (0.52 log units) above the measured one, outside the stated range (below it).
By their numbers in this assay, from the lowest: compounds 3 and 1 (each within the scatter of the next); then compound 2.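

In this assay, going by these compounds alone, hydrogen in place of fluoro on the aromatic carbon next to the ring nitrogen brings a 2.5-fold lower number from compound 2 to compound 3 (0.40 log units; beyond the scatter), the first direct reading of this fluoro, and here it goes with the weaker inhibitor of the pair. Pyridin-3-yl in place of 3-fluorophenyl gives a 1.1-fold lower number from compound 1 to compound 3 (0.06 log units; within the scatter), which lies within the scatter, so a pyridin-3-yl group without fluoro matches the 3-fluorophenyl group in this assay, although this step changes the ring nitrogen and the fluoro together. The gap first seen with the 6-fluoropyridin-3-yl group therefore goes with the fluoro on that ring rather than with the ring nitrogen alone, and nothing available explains why this fluoro raises the number.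

From the compounds shown here alone, whether a chloro, methoxy or amino group on the same carbon would behave like fluoro or like hydrogen remains open. Going by these compounds, it is also open whether an unsubstituted phenyl group would match pyridin-3-yl, which would separate the contribution of the ring nitrogen from that of the fluoro on the 3-fluorophenyl group.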